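Swapping fluoro for methoxy on a fused ring of compound 2

The compounds below may be only part of what the source reports. "The series", "measured", "known", "first", "only" and "open" are said of these compounds alone.

Compound 2, with the structure `COc1ccc(-c2cc(C(=O)Nc3nc4ccc(F)cc4s3)nc3cc(-c4ccccc4)nn23)cc1`, was tested in a functional assay on DU-145 cells (Homo sapiens) for cytotoxicity, read by MTT assay, with a stated time of 48 h; on this read-out higher numbers stand for weaker inhibition and lower numbers for stronger inhibition. Among the measured compounds shown here, there compound 2 gives 31400 nM, which is the higher of the two numbers measured so far. The other measured compound is compound 1, whose structure is `O=C(Nc1nc2ccc(F)cc2s1)c1cc(-c2ccc(F)cc2)n2nc(-c3ccccc3)cc2n1`; in this assay compound 1 gives 22900 nM. For the measured compounds named here, the step of a 1.4-fold higher number from compound 1 to compound 2 (0.14 log units; within the scatter) is the only measured step, and it stays within the scatter.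

Compound 3, with the structure `COc1ccc(-c2cc(C(=O)Nc3nc4ccc(OC)cc4s3)nc3cc(-c4ccccc4)nn23)cc1`, has not yet been measured. It differs from compound 2 by methoxy in place of fluoro on an aromatic carbon. Going by the values given here, the one measured step bears directly on this change: the step from compound 1 to compound 2 is the same swap of fluoro for methoxy, only on a different aromatic carbon, and it produced no change beyond the scatter. On that basis compound 3 is expected to show a step of a 1.1-fold higher number from compound 2 to compound 3 (0.05 log units; within the scatter), that is, no change beyond the scatter. Compound 3 is therefore estimated to give 35000 nM in this assay, within a range from 15000 nM to 85000 nM.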

Compound 3, half-maximal inhibitory concentration: 7580 nM
The estimate for compound 3 lay 4.6-fold (0.66 log units) above the measured number; measured number outside the range, below it.
By their numbers in this assay, from the lowest: compound 3; then compounds 1 and 2 (each within the scatter of the next).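

In this assay, replacing the 6-fluoro-1,3-benzothiazol-2-yl group with the 6-methoxy-1,3-benzothiazol-2-yl group gives a 4.1-fold lower number from compound 2 to compound 3 (0.62 log units; beyond the scatter), a modest gain in inhibition that lies beyond the scatter. The same exchange of fluoro for methoxy on a different aromatic carbon gave a 1.4-fold higher number from compound 1 to compound 2 (0.14 log units; within the scatter), which stayed within the scatter, so in these two steps the outcome depends on where the swap is made, and this position is the one of the two where the read-out moved. No measurement shown here explains why this position responds.

With only fluoro and methoxy shown at this position, it remains open whether the lower number is particular to methoxy or would also appear with a hydroxy group, an amine or a longer chain such as ethoxy. From the compounds shown here alone, it is also open whether the step would keep its size with fluoro rather than methoxy on the other aromatic ring, the arrangement found on that ring in compound 1.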